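This account rests on a few compounds, and the source may have more. Where it says the series, first, only, none or still open, it means among the compounds named here.

Compound 1 `Nc1nc(NCCNc2ncc(-c3ncc[nH]3)c(-c3ccc(Cl)cc3)n2)ccc1[N+](=O)[O-]`: in an ADME assay on microsomes from liver (Canis lupus familiaris) for metabolic stability (a higher number here means that the compound lasts longer, a lower number that the compound disappears faster), compound 1 gives > 0.5 h, which is a limit of the assay.
Compound 2 `Nc1nc(NCCNc2ncc(-c3ncc[nH]3)c(-c3cc(F)ccc3Cl)n2)ccc1[N+](=O)[O-]`: compound 2 gives > 0.5 h, likewise a limit.
Compound 3 `Nc1nc(NCCNc2ncc(-c3ncc[nH]3)c(-c3ccc(Cl)cc3F)n2)ccc1[N+](=O)[O-]`: compound 3 gives > 0.5 h, again a limit.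

Compound 1 thus stands only at a limit in this assay, and so do the other two (the limit of > 0.5 h in this assay, at which 3 of the 3 values shown sit). The steps a step that the two limits leave unreadable from compound 1 to compound 2, a step that the two limits leave unreadable from compound 1 to compound 3 and a step that the two limits leave unreadable from compound 2 to compound 3 are accordingly of unreadable size. Compound 4 `Nc1nc(NCCNc2ncc(-c3ncc[nH]3)c(-c3ccc(Br)cc3F)n2)ccc1[N+](=O)[O-]` differs from compound 1 in 4-bromo-2-fluorophenyl in place of 4-chlorophenyl on an aromatic carbon. Among the measured compounds shown here, no measured step resolves a change of this kind; every variation of that group seen so far has stayed at the limit. The step expected is a step that the limit leaves unreadable from compound 1 to compound 4, nothing readable beyond the scatter. Compound 4 is therefore estimated at 1 h (range 0.4 h to 3 h), most likely itself reported only as a limit.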

Compound 4, half-life: > 0.5 h
Compound 4: only a limit was reported; the forecaster's own chance of this, stated with the estimate: 85%; the middle value lies beyond the limit too.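

Compound 4 gives > 0.5 h in this assay as a limit of the assay. Among the compounds shown here, no step among compound 1, compound 2, compound 3 and compound 4 can be read: the limit of > 0.5 h in this assay, at which 4 of the 4 values shown sit. The compounds shown leave open the actual half-lives of all four and whether the phenyl substitutions change them.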